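The source may hold more compounds than are shown below. What is called first, only, known or untested is meant among the compounds shown, and "the series" means these compounds.

Series notes. Compound 1 `COc1cc(C(=O)NS(=O)(=O)c2ccccc2)ccc1Cn1ncc2ccc(NC(=O)CC3CCCC3)cc21` and compound 2 `CCCCOC(=O)Nc1ccc2cnn(Cc3ccc(-c4nn[nH]n4)cc3OC)c2c1` differ at two places, so only their two values can be set side by side. In a functional assay (trachea) for antagonist activity, with Cavia porcellus as the target (a higher number here means a more potent compound, by a factor of ten per unit of this negative logarithm, a lower number a less potent compound), compound 1 gives 10.5; compound 2 gives 7.1, the lowest of the two numbers, a gap to compound 1 beyond the scatter. Compound 3 `CCCCOC(=O)Nc1ccc2cnn(Cc3ccc(C(=O)NS(=O)(=O)c4ccccc4)cc3OC)c2c1` takes one step from compound 2: (phenylsulfonyl)carbamoyl in place of 2H-tetrazol-5-yl on an aromatic carbon. Among the compounds with values here, no measured step of this kind exists in the set. Compound 1, which carries the same entering group and gives 10.5 in this assay, points to a gain well beyond the scatter. Compound 3 is expected at 9, range 8 to 10, an upward step of a number 1.90 log units higher from compound 2 to compound 3 (beyond the scatter).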

Compound 3, negative logarithm of the antagonist equilibrium constant: 9.2
For compound 3 the middle estimate is 0.20 log units below the measured one; measured number inside the range.
By their numbers in this assay, from the lowest: compound 2; then compound 3; then compound 1.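

In this assay, within the data shown here, (phenylsulfonyl)carbamoyl in place of 2H-tetrazol-5-yl on this aromatic carbon gives a number 2.10 log units higher from compound 2 to compound 3 (beyond the scatter) as the first direct reading of this change. Butoxy in place of cyclopentylmethyl on the carbonyl carbon gives a number 1.30 log units lower from compound 1 to compound 3 (beyond the scatter) and so separates the second place from the first, each with its own step beyond the scatter. Nothing at hand accounts for either step.

Still open, from the compounds shown here alone, is whether a carboxylic acid on this aromatic carbon would match the (phenylsulfonyl)carbamoyl group. A longer chain than butoxy on the carbonyl carbon also remains to be placed against cyclopentylmethyl.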